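Swapping the diallylamine of compound 1 for a benzyl-propyl amine

A few compounds are considered here, and "the series" means these few. Any claim that something is new, unique, unknown or untested is made for them only; others in the source may bear on it.

Compound 1, `C=CCN(CC=C)Cc1c(C(F)(F)F)nc2n(-c3c(C)cc(C)cc3C)c(Cl)cn12`: 13 nM
Compound 2, `Cc1cc(C)c(-n2c(Cl)cn3c(CN(CCC(F)(F)F)Cc4cccc(F)c4)c(C(F)(F)F)nc23)c(C)c1`: 49 nM
Compound 3, `Cc1cc(C)c(-n2c(Cl)cn3c(CN(CCC(F)(F)F)Cc4ccc(F)cc4)c(C(F)(F)F)nc23)c(C)c1`: 34 nM

In an assay on cells for displacement of a labelled ligand from corticotropin-releasing factor receptor 1 (Homo sapiens), with a stated time of 100 min (a higher number here means a weaker inhibitor, a lower number a stronger inhibitor), compound 1 gives the lowest of the three numbers; compound 3 sits above it, and compound 2 higher still, both beyond the scatter. Compound 4, `CCCN(Cc1ccccc1)Cc1c(C(F)(F)F)nc2n(-c3c(C)cc(C)cc3C)c(Cl)cn12`, is not yet measured. It differs from compound 1 in one place: benzyl(propyl)amino in place of diallylamino on a saturated chain carbon bound to an aromatic carbon. For the measured compounds named here, no measured step matches this change. Going by the values given here, the only measured step, a 1.4-fold lower number from compound 2 to compound 3 (0.16 log units; within the scatter), concerns a fluorine position on a benzyl group and is within the scatter. Compounds 2 and 3 both carry a benzyl group and a saturated chain on the amine, like compound 4, and both show higher numbers than compound 1. A modest rise is therefore expected, a 2.2-fold higher number from compound 1 to compound 4 (0.33 log units; beyond the scatter). Compound 4 is estimated at 28 nM, between 10 nM and 70 nM.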

Compound 4, inhibition constant: 170 nM
For compound 4 the middle estimate is 6.1-fold (0.78 log units) below the measured one; measured number above the stated range.
By their numbers in this assay, from the lowest: compound 1; then compounds 3 and 2 (each within the scatter of the next); then compound 4.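

In this assay, the swap at this saturated chain carbon gives a 13-fold higher number from compound 1 to compound 4 (1.12 log units; beyond the scatter), so the amine group here strongly affects the number. The earlier compounds shown here showed only a move of fluorine on the benzyl group, a change within the scatter, and not what a change of the whole amine does. No measurement shown explains this rise.
The benzyl group and the propyl chain enter together, so the compounds shown leave open which one goes with the rise. Dipropylamino or allyl(benzyl)amino on the same carbon would separate the two.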